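A few compounds are considered here, and "the series" means these few. Any claim that something is new, unique, unknown or untested is made for them only; others in the source may bear on it.

Compound 1 `CCCSc1nc(N)c2nc(O)n(Cc3ccccc3)c2n1` gives 0.01 uM in a functional assay (spleen, spleen) for activation, with Mus musculus as the target; a lower number here means that less compound is needed, a higher number that more compound is needed for the effect.
Compound 2 `CCCCCSc1nc(N)c2nc(O)n(Cc3ccccc3)c2n1` gives 10 uM in this assay.

Compound 2 stands at the highest number of the two in this assay; its nearest neighbour is compound 1, a much lower number. Compound 3 `CSc1nc(N)c2nc(O)n(Cc3ccccc3)c2n1` differs from compound 2 by hydrogen in place of butyl on a saturated chain carbon bound to a sulfur, that is, pentylsulfanyl to methylsulfanyl. Among the compounds with values here, only one measured step bears on this: a 1000-fold higher number from compound 1 to compound 2 (3.00 log units; beyond the scatter). On these data alone, that step, from a shorter to a longer chain, moved strongly toward a higher number, so a shorter chain is expected to move toward a lower number, though a chain shorter than propyl is untested, and the expected step of a 100-fold lower number from compound 2 to compound 3 (2.00 log units; beyond the scatter) is therefore kept moderate. Compound 3 is expected to give about 0.1 uM, between 0.01 uM and 1 uM.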

Compound 3, minimum effective concentration: 0.1 uM
Compound 3: middle estimate and measured number agree at the digits printed, and the stated range covers the measured number.
By their numbers in this assay, from the lowest: compound 1; then compound 3; then compound 2.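

Going from the pentyl chain to the methyl group gives a 100-fold lower number from compound 2 to compound 3 (2.00 log units; beyond the scatter) in this assay, so a shorter chain on the sulfur can lower the number a great deal. Shortest is still not lowest, as there is a 10-fold higher number from compound 1 to compound 3 (1.00 log units; beyond the scatter) and the propyl chain gives the lowest number of these three compounds. Nothing shown explains why chain length acts this way.

Still open, on these data alone, is where ethyl and butyl chains would fall, and how a branched chain such as isopropyl or a chain ending in an amine would compare with propyl.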